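The source may report more compounds than this note shows. Statements on the series, on what has been measured and on what is new or still open speak of the compounds shown alone.

Compound 3 `O=C1CSC(=O)N1C[C@H]1CN(c2ccc(-n3cc(-c4ccccn4)cn3)c(F)c2)C(=O)O1` was tested in a physicochemical assay for solubility, read by HPLC, with a stated time of 24 h (a lower number here means a less soluble compound, a higher number a more soluble compound), where compound 3 gives 26900 nM. That is the lowest number among the three compounds measured, although the gap to compound 2 `O=C1CCC(=O)N1C[C@H]1CN(c2ccc(-n3cc(-c4ccccn4)cn3)c(F)c2)C(=O)O1`, which gives 45300 nM, is within the scatter, while the gap to compound 1 `CN(CCC#N)C[C@H]1CN(c2ccc(-n3cc(-c4ccccn4)cn3)c(F)c2)C(=O)O1`, which gives 64500 nM, lies beyond it. All three share one core and differ only in the group on a saturated chain carbon bound to a saturated ring carbon. The steps measured there have all been modest or smaller: a 1.4-fold lower number from compound 1 to compound 2 (0.15 log units; within the scatter), a 2.4-fold lower number from compound 1 to compound 3 (0.38 log units; beyond the scatter) and a 1.7-fold lower number from compound 2 to compound 3 (0.23 log units; within the scatter). Compound 4 `O=C1O[C@@H](CNC(=O)C(F)(F)F)CN1c1ccc(-n2cc(-c3ccccn3)cn2)c(F)c1` alters the same spot: ((trifluoromethyl)carbonyl)amino in place of 2,4-dioxo-1,3-thiazolidin-3-yl on a saturated chain carbon bound to a saturated ring carbon. Going by the values given here, no measured step brings in a group with a hydrogen-bond donor and no ring, so the bearing steps only show that swaps at this spot have stayed small. The step is therefore expected to be a 1.5-fold higher number from compound 3 to compound 4 (0.17 log units; within the scatter), leaning slightly upward. Compound 4 is thus estimated at 40000 nM, within a range of 15000 nM to 100000 nM.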

Compound 4, solubility: 114000 nM
Compound 4: middle estimate off by 2.9-fold (0.45 log units), on the low side, and the stated range ends below it.
By their numbers in this assay, from the lowest: compounds 3, 2, 1 and 4 (each within the scatter of the next, the first and the last beyond it).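

In this assay this position allows a larger swing than the earlier swaps showed: the ringless ((trifluoromethyl)carbonyl)amino group, which carries a hydrogen-bond donor, gives a 4.2-fold higher number from compound 3 to compound 4 (0.63 log units; beyond the scatter) and a 2.5-fold higher number from compound 2 to compound 4 (0.40 log units; beyond the scatter). Against compound 1, whose group also has no ring but has no hydrogen-bond donor, the step is a 1.8-fold higher number from compound 1 to compound 4 (0.25 log units; within the scatter), so compound 4 separates from the two ring-bearing groups but not from compound 1. Nothing available here accounts for these differences.

The compounds shown leave open whether the amide hydrogen or the trifluoromethyl group goes with the higher number. An acetylamino group, with methyl in place of trifluoromethyl, and the same trifluoroacetamide with a methyl on its nitrogen would pull these two features apart, while a plain amine would test removing the carbonyl as well.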